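The source may hold more compounds than are shown below. What is called first, only, known or untested is meant among the compounds shown, and "the series" means these compounds.

Three analogues sharing one core have been measured in a functional assay on WI-38 VA13 cells (Homo sapiens) for cytotoxicity; a lower number here means that less compound is needed, a higher number that more compound is needed for the effect. Compound 1 `N#Cc1cccc(C(=O)Nc2ccc3nc(NC(=O)C4CCCCC4)sc3c2)c1` gives 0.52 ug/mL, compound 2 `N#Cc1ccc(C(=O)Nc2ccc3nc(NC(=O)C4CCCCC4)sc3c2)cc1` gives 3.3 ug/mL, and compound 3 `O=C(Nc1ccc2nc(NC(=O)C3CCCCC3)sc2c1)c1c(F)cccc1C(F)(F)F` gives 0.032 ug/mL. Compound 2 thus stands at the highest number of the three. Going by the values given here, the only step between measured compounds, a 6.3-fold higher number from compound 1 to compound 2 (0.80 log units; beyond the scatter), is a change on the carbonyl carbon, and it is the one that bears on the new compound. Compound 4 `Cc1cc(C(=O)Nc2ccc3nc(NC(=O)C4CCCCC4)sc3c2)n(C)n1` differs from compound 2 by 1,3-dimethyl-1H-pyrazol-5-yl in place of 4-cyanophenyl on a carbonyl carbon. Among the compounds with values here, no measured pair exchanges the six-membered aromatic ring on the carbonyl carbon for a five-membered one, so the expectation rests loosely on that single step; the expected step of a 1.5-fold higher number from compound 2 to compound 4 (0.18 log units; within the scatter) is modest, toward a higher number. Compound 4 is estimated at 5 ug/mL, with a range from 1.5 ug/mL to 20 ug/mL.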

Compound 4, half-maximal effective concentration: 0.12 ug/mL
The estimate for compound 4 lay 42-fold (1.62 log units) above the measured number, outside the stated range (below it).
By their numbers in this assay, from the lowest: compound 3; then compound 4; then compound 1; then compound 2.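

In this assay, the group on this carbonyl carbon proves able to lower the number well beyond what the cyanophenyl compounds showed: 1,3-dimethyl-1H-pyrazol-5-yl gives a 28-fold lower number from compound 2 to compound 4 (1.44 log units; beyond the scatter) and a 4.3-fold lower number from compound 1 to compound 4 (0.64 log units; beyond the scatter). A five-membered aromatic ring with 2 hetero atoms is thus tolerated here, and compound 4 lies below both cyanophenyl compounds. Nothing available explains this difference. From the compounds shown here alone, it remains open whether the two methyl groups matter to the 1,3-dimethyl-1H-pyrazol-5-yl result, and whether a saturated amine such as morpholine on this carbonyl carbon would move the number the same way.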